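The source may report more compounds than this note shows. Statements on the series, on what has been measured and on what is new or still open speak of the compounds shown alone.

In a functional assay on HL-60 cells (Homo sapiens) for cytotoxicity, read by WST assay, with a stated time of 48 h (on this read-out higher numbers stand for an effect only at larger amounts of compound and lower numbers for an effect already at smaller amounts), compound 3 `O=C1OC[C@H](Cc2ccccc2F)[C@H]1Cc1ccc(Cl)c(Cl)c1` gives 28000 nM, within the scatter of both compound 1 `O=C1OC[C@H](Cc2ccccc2)[C@H]1Cc1ccc(Cl)c(Cl)c1` at 19000 nM and compound 2 `CCOc1ccccc1C[C@H]1COC(=O)[C@@H]1Cc1ccc(Cl)c(Cl)c1` at 15000 nM. Compound 4 `O=C1OC[C@H](Cc2ccc(O)cc2)[C@H]1Cc1ccc(Cl)c(Cl)c1` has 4-hydroxyphenyl in place of 2-fluorophenyl on a saturated chain carbon bound to a saturated ring carbon. The nearest evidence comes from swaps on an aromatic carbon: a 1.5-fold higher number from compound 1 to compound 3 (0.17 log units; within the scatter), a 1.3-fold lower number from compound 1 to compound 2 (0.10 log units; within the scatter) and a 1.9-fold higher number from compound 2 to compound 3 (0.27 log units; within the scatter), all within the scatter. Going by the values given here, no measured compound carries a hydroxy group, so this evidence is indirect. In this assay, no step beyond the scatter is therefore expected, and the estimate is a 1.4-fold lower number from compound 3 to compound 4 (0.15 log units; within the scatter). Compound 4 is estimated at 20000 nM, with an expected range of 9000 nM to 45000 nM.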

Compound 4, half-maximal effective concentration: 37000 nM
Compound 4: the middle estimate sits 1.9-fold (0.27 log units) below what was measured, within the range that was stated.
By their numbers in this assay, from the lowest: compounds 2, 1, 3 and 4 (each within the scatter of the next, the first and the last beyond it).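

In this assay, the hydroxy group brings a hydrogen-bond donor, the only one among the compounds shown, yet the steps stay small: a 1.3-fold higher number from compound 3 to compound 4 (0.12 log units; within the scatter) and a 1.9-fold higher number from compound 1 to compound 4 (0.29 log units; within the scatter). Among the compounds shown, the aromatic group on this saturated chain carbon thus accepts a hydroxy group in the 4-position without a listed step beyond the scatter. Only compound 2 and compound 4 lie beyond the scatter of each other. Nothing available explains these small steps. On these data alone, whether an amine or a carboxylic acid in place of the hydroxy group would move the number beyond the scatter stays open.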